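The source may report more compounds than this note shows. Statements on the series, on what has been measured and on what is new or still open speak of the compounds shown alone.

Compound 3 `COc1cc(N)c(Cl)cc1NC(=O)C1CCN(C/C=C/c2ccccc2)CC1` was tested in a functional assay on the whole organism for antagonist activity, with Mus musculus as the target (on this read-out higher numbers stand for an effect only at larger amounts of compound and lower numbers for an effect already at smaller amounts), alongside two companions that share its core and differ only in the group on a saturated chain carbon bound to an amine nitrogen in a ring. In this assay compound 3 gives > 10 mg/kg, which is a limit of the assay and not a number. Compound 1 `CCCCCCCN1CCC(C(=O)Nc2cc(Cl)c(N)cc2OC)CC1`, carrying a hexyl group at that place, gives > 10 mg/kg in this assay, again a limit. Compound 2 `COc1cc(N)c(Cl)cc1NC(=O)C1CCN(CC2CC2)CC1`, with a cyclopropyl group there, gives > 10 mg/kg in this assay, also a limit. The three steps among them, a step that the two limits leave unreadable from compound 1 to compound 2, a step that the two limits leave unreadable from compound 1 to compound 3 and a step that the two limits leave unreadable from compound 2 to compound 3, therefore cannot be read for size, because of the limit of > 10 mg/kg in this assay, at which 3 of the 3 values shown sit.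

Compound 4 `CCCN1CCC(C(=O)Nc2cc(Cl)c(N)cc2OC)CC1` is the next member of the series. It differs from compound 3 by ethyl in place of 2-phenylethenyl on a saturated chain carbon bound to an amine nitrogen in a ring. All three measured steps touch the same place but none of them is readable, so no direction can be taken from them. Compound 4 is expected to stay with its companions in this assay, so the step that the limit leaves unreadable from compound 3 to compound 4 is estimated as no change that can be seen. The estimate for compound 4 is 15 mg/kg, with a range from 5 mg/kg to 50 mg/kg.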

Compound 4, dose for half-maximal effect: > 10 mg/kg
Compound 4: only a limit was reported; the forecaster's own chance of this, stated with the estimate: 75%; the middle value lies beyond the limit too.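

The new steps from compound 1, compound 2 and compound 3 to compound 4 cannot be read for size, because compound 4 ends at the same limit as the others in this assay: the limit of > 10 mg/kg in this assay, at which 4 of the 4 values shown sit. The compounds shown leave open whether the group on a saturated chain carbon bound to an amine nitrogen in a ring has any bearing on the result in this assay.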